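This account rests on a few compounds, and the source may have more. Where it says the series, first, only, none or still open, it means among the compounds named here.

Compound 1, `CC(C)[C@H]1C(O)=C(C2=NS(=O)(=O)c3c(O)cccc32)C(=O)N1Cc1ccccc1`, gives > 1 h in an in vitro ADME assay on microsomes from liver (Homo sapiens) for metabolic stability (on this read-out higher numbers stand for a longer-lived compound and lower numbers for a shorter-lived compound), which is a limit of the assay rather than a number.
Compound 2, `CC(C)[C@H]1C(O)=C(C2=NS(=O)(=O)c3c(OCC#N)cccc32)C(=O)N1Cc1ccccc1`, gives > 1 h in this assay, again a limit rather than a measured number.

Compound 2 therefore stands at the limit of this assay, and so does compound 1: the limit of > 1 h in this assay, at which 2 of the 2 values shown sit. Among the measured compounds shown here, the one step between measured compounds, a step that the two limits leave unreadable from compound 1 to compound 2, is consequently unreadable, since both ends of it are limits and no number is known for either.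

Compound 3, `CC(C)[C@H]1C(O)=C(C2=NS(=O)(=O)c3c(OCC(=O)N4CCOCC4)cccc32)C(=O)N1Cc1ccccc1`, differs from compound 2 in one place: (morpholin-4-yl)carbonyl in place of cyano on a saturated chain carbon bound to an oxygen on an aromatic ring. For the measured compounds named here, the only measured step that bears on this change is the one from compound 1 to compound 2, and it gives no readable size. What the two limits do show is that neither the free hydroxyl of compound 1 nor the cyanomethoxy group of compound 2 brought the half-life into the readable range.

On that thin basis compound 3 is expected to show a step that the limit leaves unreadable from compound 2 to compound 3 in this assay, which is to say no step beyond the scatter. Compound 3 is accordingly estimated at 1.5 h, with a range from 0.5 h to 4 h, and the outcome may well again be reported as a limit rather than a number.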

Compound 3, half-life: > 1 h
Compound 3: only a limit was reported; the forecaster's own chance of this, stated with the estimate: 60%; the middle value does not contradict the limit.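

In this assay compound 3 gives > 1 h, which is a limit and not a number. Among the compounds shown here, no step among compound 1, compound 2 and compound 3 can be read, because all three rest on the same limit: the limit of > 1 h in this assay, at which 3 of the 3 values shown sit. The compounds shown leave open the actual half-life of each compound and whether the groups on an oxygen on an aromatic ring differ at all.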